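A few compounds are considered here, and "the series" means these few. Any claim that something is new, unique, unknown or untested is made for them only; others in the source may bear on it.

In a functional assay on MCF7 cells (Homo sapiens) for cytotoxicity, read by MTT assay, with a stated time of 72 h (on this read-out lower numbers stand for stronger inhibition and higher numbers for weaker inhibition), three compounds that share one core have been measured so far. Compound 1 `COc1cc2ncnc(Nc3ccc(F)c(Cl)c3)c2cc1NC(=O)N/N=C/c1ccc(F)cc1` gives 35100 nM, compound 2 `COc1cc2ncnc(Nc3ccc(F)c(Cl)c3)c2cc1NC(=O)N/N=C/c1cccc(Br)c1` gives 27100 nM, and compound 3 `COc1cc2ncnc(Nc3ccc(F)c(Cl)c3)c2cc1NC(=O)N/N=C/c1cc(Br)c(O)c(Br)c1` gives 30200 nM. On these numbers, compound 3 cannot be told apart from the other two.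

The next compound, compound 4 `COc1cc2ncnc(Nc3ccc(F)c(Cl)c3)c2cc1NC(=O)N/N=C/c1ccc(O)cc1`, has 4-hydroxyphenyl in place of 3,5-dibromo-4-hydroxyphenyl on a carbon with a double bond to nitrogen.

Three measured steps change the group at that same carbon: a 1.3-fold lower number from compound 1 to compound 2 (0.11 log units; within the scatter), a 1.2-fold lower number from compound 1 to compound 3 (0.07 log units; within the scatter) and a 1.1-fold higher number from compound 2 to compound 3 (0.05 log units; within the scatter). All three lie within the scatter, so among these compounds no swap at this carbon has yet produced a clear change. As far as these compounds go, none of them carries 4-hydroxyphenyl, however, so the new group itself is untested. No step beyond the scatter is therefore expected in this assay. The estimated step is a 1.0-fold lower number from compound 3 to compound 4 (0.00 log units; within the scatter). For compound 4 the estimated value is 30000 nM, with an expected range from 15000 nM to 60000 nM.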

Compound 4, half-maximal inhibitory concentration: 28600 nM
Beside the measured number, compound 4's estimate is 1.0-fold (0.02 log units) above it, within the range that was stated.
By their numbers in this assay, from the lowest: compounds 2, 4, 3 and 1 (each within the scatter of the next).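

In this assay, taking both bromine atoms off the 3,5-dibromo-4-hydroxyphenyl group gives a 1.1-fold lower number from compound 3 to compound 4 (0.02 log units; within the scatter) and so produces no clear change. The other two steps to 4-hydroxyphenyl also stay within the scatter: replacing 3-bromophenyl gives a 1.1-fold higher number from compound 2 to compound 4 (0.02 log units; within the scatter) and hydroxy in place of fluoro on an aromatic carbon gives a 1.2-fold lower number from compound 1 to compound 4 (0.09 log units; within the scatter), so all four substituted phenyl groups on this carbon read alike in this set. No supporting data explain this similarity.

As far as these compounds go, all four compounds carry a phenyl ring at this carbon, so it remains open whether a longer alkyl chain or a ring bearing an amine or a carboxylic acid would shift the number beyond the scatter. Changes elsewhere on the shared core also remain open.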